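This account rests on a few compounds, and the source may have more. Where it says the series, first, only, none or still open, it means among the compounds named here.

Measured compounds:
- compound 1, `O=c1oc2ccc(Br)cc2c(=O)n1-c1ccc(F)cc1F`: 16000 nM
- compound 2, `O=C(Nc1ccc(I)cc1F)c1cc(I)ccc1O`: 6000 nM
- compound 3, `O=C(Nc1ccc(I)cc1F)c1cc(F)ccc1O`: 7400 nM

In an ADME assay on RAW264.7 cells (Mus musculus) for cytotoxicity, read by MTT assay, with a stated time of 24 h (a lower number here means that less compound is tolerated, a higher number that more compound is tolerated), compound 1 gives the highest number of the three, so more of it is tolerated than of compound 2 or compound 3, and both of those gaps lie beyond the usual scatter. Going by the values given here, compound 2 and compound 3 share a different core from compound 1; the only step between measured compounds that differ in one place is a 1.2-fold higher number from compound 2 to compound 3 (0.09 log units; within the scatter), a halogen swap on an aromatic carbon that leaves the number essentially where it was.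

Compound 4, `O=c1oc2ccc(I)cc2c(=O)n1-c1ccc(F)cc1F`, is not yet measured. It differs from compound 1 as follows: iodo in place of bromo on an aromatic carbon. Among the compounds with values here, this is again a halogen-for-halogen exchange on an aromatic carbon, and the one comparable step, from compound 2 to compound 3, stayed within the scatter. On that basis the step from compound 1 to compound 4 in this assay is expected to be small, with no clear direction, estimated as a 1.1-fold lower number from compound 1 to compound 4 (0.03 log units; within the scatter). For compound 4 a value of about 15000 nM is therefore expected, most likely between 7000 nM and 32000 nM.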

Compound 4, half-maximal cytotoxic concentration: 15700 nM
Compound 4: middle estimate off by 1.0-fold (0.02 log units), on the low side; measured number inside the range.
By their numbers in this assay, from the lowest: compounds 2 and 3 (each within the scatter of the next); then compounds 4 and 1 (each within the scatter of the next).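

In this assay the exchange of bromo for iodo on this aromatic carbon of the core of compound 1 gives a 1.0-fold lower number from compound 1 to compound 4 (0.01 log units; within the scatter) and so shows no measurable response to this change at this position. The earlier exchange of iodo for fluoro gave a 1.2-fold higher number from compound 2 to compound 3 (0.09 log units; within the scatter) on a different core, so a halogen swap on an aromatic carbon now stays within the scatter on both cores shown, and neither step goes against this. Nothing available speaks to why the number holds steady across this exchange.

As far as these compounds go, only bromo and iodo are seen at this carbon, so the effect of fluoro, chloro, methoxy, an amine or a carboxylic acid here remains open. Also open, from the compounds shown here alone, is how the number responds to replacing the fluoro groups on the separate aromatic ring of compound 1.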